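A few compounds are considered here, and "the series" means these few. Any claim that something is new, unique, unknown or untested is made for them only; others in the source may bear on it.

Three penicillin-type compounds, all carrying the same benzhydryl ester on the shared core, have been tested in a functional assay on OE19 cells (Homo sapiens) for cytotoxicity, read by MTT assay, with a stated time of 48 h; a lower number here means a stronger inhibitor, a higher number a weaker inhibitor. Compound 1 `CC1(C)[C@H](C(=O)OC(c2ccccc2)c2ccccc2)N2C(=O)/C(=C/C(=O)c3ccc([N+](=O)[O-])cc3)[C@H]2[S+]1[O-]` gives 92400 nM. Compound 2 `CC1(C)S[C@@H]2/C(=C\C(=O)c3ccccc3)C(=O)N2[C@H]1C(=O)OC(c1ccccc1)c1ccccc1` gives 12800 nM, the lowest of the three numbers and well beyond the scatter from the others. Compound 3 `CC1(C)S[C@@H]2C/C(=C\C(=O)c3ccccc3)C(=O)N2[C@H]1C(=O)OC(c1ccccc1)c1ccccc1`, which lacks the double bond in the ring, gives 73300 nM.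

Compound 4 `COC(=O)/C=C1/C(=O)N2[C@@H]1SC(C)(C)[C@@H]2C(=O)OC(c1ccccc1)c1ccccc1` is not yet measured. It differs from compound 2 in one place: methoxy in place of phenyl on a carbonyl carbon. Going by the values given here, no measured pair here shows such a change, so its effect can only be guessed. Among the compounds with values here, since the strongest compound so far keeps a benzoyl group, a modest loss is expected, with the step of a 2.7-fold higher number from compound 2 to compound 4 (0.44 log units; beyond the scatter) lying beyond the scatter. Compound 4 is thus estimated at 35000 nM, plausibly between 10000 nM and 120000 nM.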

Compound 4, half-maximal inhibitory concentration: 20200 nM
Estimate against measurement, compound 4: 1.7-fold (0.24 log units) above; low and high end bracket the measured number.
By their numbers in this assay, from the lowest: compounds 2 and 4 (each within the scatter of the next); then compounds 3 and 1 (each within the scatter of the next).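

Swapping benzoyl for methoxycarbonyl gives a 1.6-fold higher number from compound 2 to compound 4 (0.20 log units; within the scatter) in this assay, so the two compounds cannot be told apart. At this carbonyl carbon, then, the phenyl ring is not required to hold the number at this level, and methoxy, with no ring, serves as well. Nothing available explains why the two groups read alike. An amine or a carboxylic acid on this same carbonyl carbon remains untested among the compounds shown. From the compounds shown here alone, whether methoxy would read the same on the core of compound 1 or compound 3 also stays open.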